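Amino in place of chloro on a fused benzamide-type core

The source may hold more compounds than are shown below. What is called first, only, known or untested is meant among the compounds shown, and "the series" means these compounds.

Compound 1: `Nc1nn(C(=O)Nc2ccc(Cc3ccccc3)cc2)c2ccccc12` — 11500 nM
Compound 2: `Nc1nn(C(=O)Nc2ccc(Cc3ccccc3)cc2)c2ccc(Cl)cc12` — 18500 nM

In a functional assay on SK-MEL-28 cells (Homo sapiens) for antiproliferative activity, read by sulforhodamine B assay, with a stated time of 48 h (a higher number here means a weaker inhibitor of growth, a lower number a stronger inhibitor of growth), compound 1 gives 11500 nM and compound 2 gives 18500 nM. Among the compounds with values here, compound 2 is one of only two measured compounds, and its nearest neighbour is compound 1: the step of a 1.6-fold higher number from compound 1 to compound 2 (0.21 log units; within the scatter) shows that placing chloro on that aromatic carbon leaves the read-out essentially unchanged.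

Compound 3, `Nc1ccc2c(c1)c(N)nn2C(=O)Nc1ccc(Cc2ccccc2)cc1`, differs from compound 2 by amino in place of chloro on an aromatic carbon. Within the data shown here, the one measured step that bears on this position, a 1.6-fold higher number from compound 1 to compound 2 (0.21 log units; within the scatter), indicates the position tolerates a change from hydrogen to chloro without a shift beyond the scatter; there is no measured step for an amino group at this position, so the direction of any shift is not settled. Compound 3 is therefore expected to remain close to compound 2, with the step of a 1.2-fold lower number from compound 2 to compound 3 (0.09 log units; within the scatter) predicted to fall within the scatter. The estimate for compound 3 in this assay is 15000 nM, with a range from 5000 nM to 50000 nM.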

Compound 3, concentration for 50% growth inhibition: 13700 nM
Compound 3: middle estimate off by 1.1-fold (0.04 log units), on the high side; measured number inside the range.
By their numbers in this assay, from the lowest: compounds 1, 3 and 2 (each within the scatter of the next).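

In this assay, the change from chloro to amino on this aromatic carbon gives a 1.4-fold lower number from compound 2 to compound 3 (0.13 log units; within the scatter) and the change from hydrogen to amino gives a 1.2-fold higher number from compound 1 to compound 3 (0.08 log units; within the scatter), so the position now has a second replacement for hydrogen, and neither step leaves the scatter. Hydrogen, chloro and amino on this carbon thus give three compounds whose numbers all lie within the scatter of one another, and the amino group, with its hydrogen-bond donor and hydrogen-bond acceptor where chloro counts neither, brings no measurable shift in growth inhibition in this set. No independent measurement is available here that bears on why the read-out stays flat across these three groups.

The compounds shown leave open whether a carboxylic acid, a methoxy group or a longer chain such as butoxy on this same aromatic carbon would move the number beyond the scatter. With the rest of the molecule held constant in all three compounds, they also leave open whether changes elsewhere, such as replacing the amino group already on the shared core, would do so.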